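The compounds below may be only part of what the source reports. "The series", "measured", "known", "first", "only" and "open" are said of these compounds alone.

The series centers on a shared core bearing a benzoic acid attached to a second aromatic ring, which is joined through a short chain to an imidazole. Compound 1 `O=C(O)c1ccccc1-c1ccc(CCc2ncc(Cc3ccc(Cl)cc3)[nH]2)cc1` carries a 4-chlorobenzyl group on that imidazole. In an in vitro functional assay on cells for agonist activity at Bombesin receptor subtype-3 (Mus musculus), read by luminescence and calcium flux (on this read-out higher numbers stand for an effect only at larger amounts of compound and lower numbers for an effect already at smaller amounts), compound 1 gives 102 nM, the lowest of the two numbers recorded so far. Compound 2 `CCCCc1cnc(/C=C/c2ccc(-c3ccccc3C(=O)O)cc2)[nH]1`, which carries a butyl group on the imidazole and a rigid two-carbon linker, gives in this assay a far higher reading of 10000 nM, a gap well beyond the usual scatter.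

Compound 3 `O=C(O)c1ccccc1-c1ccc(CCc2ncc(CC3CCCCCC3)[nH]2)cc1` has not yet been measured. It differs from compound 1 in one place: cycloheptyl in place of 4-chlorophenyl on a saturated chain carbon bound to an aromatic carbon. Within the data shown here, because compound 1 gives 102 nM and no pair of measured compounds differing in a single position is available, the size of this step can only be guessed. The step from compound 1 to compound 3 in this assay is expected to be a 2.9-fold higher number from compound 1 to compound 3 (0.47 log units; beyond the scatter), a modest move toward a higher number, close to the edge of the scatter. Compound 3 is therefore expected to give about 300 nM in this assay, within a range of 60 nM to 1500 nM.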

Compound 3, half-maximal effective concentration: 5.7 nM
Compound 3: middle estimate off by 53-fold (1.72 log units), on the high side; measured number outside the range, below it.
By their numbers in this assay, from the lowest: compound 3; then compound 1; then compound 2.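

Putting cycloheptyl in place of 4-chlorophenyl, on a saturated chain carbon bound to an aromatic carbon, gives in this assay an 18-fold lower number from compound 1 to compound 3 (1.25 log units; beyond the scatter), a large step beyond the scatter. This position therefore needs neither an aromatic ring nor a chlorine to give a low number in this series, and a seven-membered non-aromatic carbon ring with the same count of heavy atoms goes with a much lower number than the 4-chlorophenyl group. Compounds 1 and 2 differ in more than one place, so this is the first step that isolates the group at this position, although no measurement shown accounts for its size.

The single step changes the ring size, removes the aromatic ring and removes the chlorine all at once, so the compounds shown cannot assign the shift to any one of these changes; an unsubstituted phenyl or a cyclohexyl at this position would separate them. Going by these compounds, it also remains open whether cycloheptyl would give a similar step on a core with the two-carbon alkene linker of compound 2.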